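Trifluorophenyl cinnamamide: an expectation from three methoxy analogs

This account rests on a few compounds, and the source may have more. Where it says the series, first, only, none or still open, it means among the compounds named here.

Measured compounds:
- Compound 1, `COc1cc(C(=O)c2cc(OC)c(OC)c(OC)c2)cc(NC(=O)/C=C/c2cc(OC)c(OC)c(OC)c2)c1OC`, in a functional assay on B16 cells (Mus musculus) for cytotoxicity, read by MTT assay, with a stated time of 72 h; a higher number here means a weaker inhibitor, a lower number a stronger inhibitor: compound 1 gives 2500 nM.
- Compound 2, `COc1ccc(/C=C/C(=O)Nc2cc(C(=O)c3cc(OC)c(OC)c(OC)c3)cc(OC)c2OC)cc1`: compound 2 gives 9400 nM.
- Compound 3, `COc1ccc(/C=C/C(=O)Nc2cc(C(=O)c3cc(OC)c(OC)c(OC)c3)cc(OC)c2OC)cc1N`: compound 3 gives 12700 nM.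

Compound 3 has the highest number of the three. Its nearest neighbour is compound 2, and that gap, a 1.4-fold higher number from compound 2 to compound 3 (0.13 log units; within the scatter), is within the scatter, so the two cannot be ordered. Its furthest neighbour is compound 1, and that gap, a 5.1-fold higher number from compound 1 to compound 3 (0.71 log units; beyond the scatter), is beyond the scatter.

Compound 4, `COc1cc(C(=O)c2cc(OC)c(OC)c(OC)c2)cc(NC(=O)/C=C/c2cc(F)c(F)c(F)c2)c1OC`, differs from compound 3 by 3,4,5-trifluorophenyl in place of 3-amino-4-methoxyphenyl on a double-bonded chain carbon bound to a double-bonded chain carbon. Within the data shown here, no measured step touches a fluorinated ring, so the only bearing comes from the two replacements of the trimethoxyphenyl group: a 3.8-fold higher number from compound 1 to compound 2 (0.58 log units; beyond the scatter) and a 5.1-fold higher number from compound 1 to compound 3 (0.71 log units; beyond the scatter), both modest weakenings. Changing the group once more, this time to one without any methoxy, is expected to give a number at least as high, so compound 4 is expected to show a 1.3-fold higher number from compound 3 to compound 4 (0.10 log units; within the scatter) in this assay. The estimate for compound 4 is 16000 nM, with a range from 4000 nM to 60000 nM.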

Compound 4, half-maximal inhibitory concentration: 5200 nM
Estimate against measurement, compound 4: 3.1-fold (0.49 log units) above; measured number inside the range.
By their numbers in this assay, from the lowest: compound 1; then compounds 4, 2 and 3 (each within the scatter of the next, the first and the last beyond it).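

In this assay, the ring on this double-bonded chain carbon can lose every methoxy group without the number climbing further: 3,4,5-trifluorophenyl in place of 3-amino-4-methoxyphenyl gives a 2.4-fold lower number from compound 3 to compound 4 (0.39 log units; beyond the scatter) and, against the 4-methoxyphenyl ring, a 1.8-fold lower number from compound 2 to compound 4 (0.26 log units; within the scatter) so those two cannot be ordered. The 3,4,5-trimethoxyphenyl ring still holds the lowest number, with a 2.1-fold higher number from compound 1 to compound 4 (0.32 log units; beyond the scatter) as the cost of replacing it, so the fluorinated ring recovers only part of what the other replacements gave up. Nothing measured here explains why these rings rank as they do.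

The compounds shown leave open how a plain phenyl, a chlorophenyl or a hydroxyphenyl ring would compare at this place. Going by these compounds, whether a trifluoromethyl group on the ring would keep the number near that of compound 4 also stays open.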